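Amide-nitrogen substituents: hydroxymethylcyclopropyl to carboxycyclopropyl

The compounds below may be only part of what the source reports. "The series", "measured", "known", "first", "only" and "open" are said of these compounds alone.

The series shares one core and varies the group on the amide-type nitrogen. In a functional assay on PC-3 cells (Homo sapiens) for antiproliferative activity, read by MTT assay, with a stated time of 24 h (on this read-out lower numbers stand for stronger inhibition and higher numbers for weaker inhibition), compound 1 `CCn1c(C(=O)NCCNC(=O)OC(C)(C)C)ccc1C(CC)(CC)c1ccc(OCS(=O)(=O)c2ccccc2)c(C)c1` gives only a limit, > 50000 nM. Compound 2 `CCn1c(C(=O)N[C@H](C)CO)ccc1C(CC)(CC)c1ccc(OCS(=O)(=O)c2ccccc2)c(C)c1` gives 7790 nM, and compound 3 `CCn1c(C(=O)NC2(CO)CC2)ccc1C(CC)(CC)c1ccc(OCS(=O)(=O)c2ccccc2)c(C)c1` gives 3560 nM, the lowest of the two numbers given here; the step of a 2.2-fold lower number from compound 2 to compound 3 (0.34 log units; beyond the scatter) is modest. The steps of an at least 6.4-fold lower number from compound 1 to compound 2 (0.80 log units; beyond the scatter) and an at least 14-fold lower number from compound 1 to compound 3 (1.14 log units; beyond the scatter) are at least modest and large, though both rest on the limit (the limit of > 50000 nM in this assay, at which 1 of the 3 values shown sits).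

Compound 4 `CCn1c(C(=O)NC2(C(=O)O)CC2)ccc1C(CC)(CC)c1ccc(OCS(=O)(=O)c2ccccc2)c(C)c1` differs from compound 3 by carboxy in place of hydroxymethyl on a saturated ring carbon. Going by the values given here, no measured step changes the hydroxymethyl itself; the three steps above all concern the whole amide-nitrogen substituent, and the cyclopropyl that accompanies the modest gain in this assay from compound 2 to compound 3 is kept in compound 4. On these data alone, the carboxy group is untested, so a step around or somewhat above the scatter is expected, with a weaker number more likely than a stronger one, and a 2.0-fold higher number from compound 3 to compound 4 (0.29 log units; within the scatter) is the expected change. For compound 4 the estimate in this assay is 7000 nM, with a range from 2000 nM to 30000 nM.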

Compound 4, half-maximal inhibitory concentration: 26300 nM
Beside the measured number, compound 4's estimate is 3.8-fold (0.57 log units) below it; the measured number falls inside the stated range.
By their numbers in this assay, from the lowest: compound 3; then compound 2; then compound 4. At a limit, above all of these: compound 1.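

Going by these compounds alone, with the 1-substituted cyclopropyl kept, this is the first change to the hydroxymethyl itself, and in this assay carboxy in its place on the saturated ring carbon gives a 7.4-fold higher number from compound 3 to compound 4 (0.87 log units; beyond the scatter) and so outweighs the earlier gain between the two hydroxymethyl compounds. The cyclopropyl alone therefore does not hold that gain, as the whole-substituent comparison also shows: a 3.4-fold higher number from compound 2 to compound 4 (0.53 log units; beyond the scatter) for 1-carboxycyclopropyl in place of 1-(hydroxymethyl)ethyl. The comparison with the Boc-protected aminoethyl amide gives only a floor, an at least 1.9-fold lower number from compound 1 to compound 4 (0.27 log units; that floor lies within the scatter) and compound 1 is read at a limit: the limit of > 50000 nM in this assay, at which 1 of the 4 values shown sits.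

On these data alone, whether a methyl ester or primary amide on the same ring carbon would stay nearer compound 3 remains open. So does whether an amine or a longer hydroxyalkyl chain there would be tolerated.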